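This account rests on a few compounds, and the source may have more. Where it says the series, first, only, none or still open, it means among the compounds named here.

Measured so far in an ADME assay on S9 fraction from liver (Rattus norvegicus) for metabolic stability, read by LC-MS, using NADPH, with a stated time of 30 min; on this read-out lower numbers stand for a less stable compound and higher numbers for a more stable compound:
- compound 1 `CCCCCCCCc1ccc(OCC(=O)Cn2cnnn2)cc1`: 22%
- compound 2 `CCCCCCCCc1ccc(OCC(=O)Cn2nnc(C)n2)cc1`: < 5% (a limit)
- compound 3 `CCCCCCCCc1ccc(OCC(=O)Cn2nnc(SC)n2)cc1`: < 5% (a limit)

Compound 3 has no number, only the limit < 5%. Its place in the series is the limit of < 5% in this assay, at which 2 of the 3 values shown sit.

Compound 4 `CCCCCCCCc1ccc(OCC(=O)Cn2nnc(-c3cccc(Cl)c3)n2)cc1` carries 3-chlorophenyl in place of methylsulfanyl, on an aromatic carbon of a five-membered aromatic ring with 4 nitrogen (3-chlorophenyl in place of methylsulfanyl on an aromatic carbon).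

Among the measured compounds shown here, two measured steps bear on this change: a number at least 17 percentage points lower from compound 1 to compound 2 (beyond the scatter), and a number at least 17 percentage points lower from compound 1 to compound 3 (beyond the scatter). Both lie beyond the scatter, and both replace 1H-tetrazol-1-yl with a substituted 2H-tetrazol-2-yl group, the type of group that compound 4 keeps. The exchange most like the present one, a step that the two limits leave unreadable from compound 2 to compound 3, gives no size. For the measured compounds named here, no measured compound has a ring at this place, so the expectation is looser on the upper side.

In this assay, no step beyond the scatter is expected, and another report of a limit is likely. The step expected is a step that the limit leaves unreadable from compound 3 to compound 4. The estimate for compound 4 is 4%, with an expected range from 1% to 12%.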

Compound 4, percent of the compound remaining: 69%
Compound 4: the middle estimate sits 65 percentage points below what was measured; measured number above the stated range.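

In this assay, among the compounds shown here, the aromatic carbon of the five-membered ring with 4 nitrogen proves far more sensitive to the choice of group than the earlier compounds could show: 3-chlorophenyl gives a number at least 64 percentage points higher from compound 3 to compound 4 (beyond the scatter), and in place of methyl it gives a number at least 64 percentage points higher from compound 2 to compound 4 (beyond the scatter). Both steps start from a limit and not from a number, so they fix only a smallest size: the limit of < 5% in this assay, at which 2 of the 4 values shown sit. The earlier link between a substituted 2H-tetrazol-2-yl group and a lower read-out therefore does not hold across the series, as compound 4 goes against it, with 69% against 22% for compound 1, which has the unsubstituted 1H-tetrazol-1-yl group.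

The compounds shown leave open whether the step belongs to the aromatic ring or to its chlorine, a question that a plain phenyl group or a cyclohexyl group at this place would help to separate. They also leave open whether a ring with a nitrogen, such as a pyridyl group, would give a similar read-out in this assay.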